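Removing one hydroxy from the dihydroxyphenyl compound

The source may report more compounds than this note shows. Statements on the series, on what has been measured and on what is new or still open speak of the compounds shown alone.

Values in a functional assay on DU-145 cells (Homo sapiens) for cytotoxicity; on this read-out lower numbers stand for stronger inhibition of growth and higher numbers for weaker inhibition of growth:
- compound 1 `COc1ccc(C2=C(c3ccc(SC)cc3)CC3CCCN3C2=O)cc1Br`: 900 nM
- compound 2 `COc1ccc(C2=C(c3ccc(SC)cc3)CC3CCCN3C2=O)cc1C`: 900 nM
- compound 3 `CSc1ccc(C2=C(c3ccc(O)c(O)c3)C(=O)N3CCCC3C2)cc1`: 60000 nM

Compound 3 has the highest of the three numbers, and it lies well clear of the other two. The measured steps to it are large: a 67-fold higher number from compound 1 to compound 3 (1.82 log units; beyond the scatter), and a 67-fold higher number from compound 2 to compound 3 (1.82 log units; beyond the scatter). Exchanging bromo for methyl leaves the number unmoved: no change at the digits printed from compound 1 to compound 2 (within the scatter).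

Compound 4 `CSc1ccc(C2=C(c3ccc(O)cc3)C(=O)N3CCCC3C2)cc1` is compound 3 with one change: hydrogen in place of hydroxy on an aromatic carbon. This turns 3,4-dihydroxyphenyl into 4-hydroxyphenyl. For the measured compounds named here, no measured step isolates this change, so the two large steps to compound 3 serve only as an upper guide. Compound 4 keeps one hydroxy and has neither the methoxy nor the bromo or methyl of the two lower compounds, so only a partial return towards them is expected. The expected step is a 10-fold lower number from compound 3 to compound 4 (1.00 log units; beyond the scatter), which is towards a lower number and beyond the scatter. For compound 4 the estimated value is 6000 nM, with a range of 1200 nM to 30000 nM.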

Compound 4, concentration for 50% growth inhibition: > 100000 nM
Compound 4 was reported as a limit; the forecaster's own chance of this, stated with the estimate: 10%; middle value at least 16-fold (1.22 log units) from the limit.
By their numbers in this assay, from the lowest: compounds 1 and 2 (each within the scatter of the next); then compound 3. At a limit, above all of these: compound 4.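

Compound 4 is reported only as a limit in this assay: the limit of > 100000 nM in this assay, at which 1 of the 4 values shown sits.

Replacing hydroxy with hydrogen brings no measured return towards compounds 1 and 2, and the step reads an at least 1.6-fold higher number from compound 3 to compound 4 (0.22 log units; that floor lies within the scatter). The 4-hydroxyphenyl group therefore stays far from the two substituted methoxyphenyl groups, with an at least 110-fold higher number from compound 2 to compound 4 (2.04 log units; beyond the scatter) and an at least 110-fold higher number from compound 1 to compound 4 (2.04 log units; beyond the scatter), so the loss of the second hydroxy does not recover growth inhibition.

Compound 3 and compound 4 cannot be placed apart beyond the scatter, since the true value of compound 4 is not given. On these data alone, it also remains open whether 4-methoxyphenyl alone, or an amine in place of the remaining hydroxy, would move the number towards that of compound 1.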